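The source may report more compounds than this note shows. Statements on the series, on what has been measured and on what is new or still open speak of the compounds shown alone.

Measured so far in a functional assay on A498 cells (Homo sapiens) for inhibition, read by sulforhodamine B assay, with a stated time of 48 h, tested at 10 uM; on this read-out higher numbers stand for a weaker effect at the one concentration tested and lower numbers for a stronger effect:

compound 1 `O=C(Nc1cccc(-n2cc(-c3ccncc3)c(-c3cc(O)cc(Cl)c3)n2)c1)Nc1ccc(Cl)c(C(F)(F)F)c1` gives 21.5%
compound 2 `O=C(Nc1cccc(-n2cc(-c3ccncc3)c(-c3cc(O)cc(Cl)c3)n2)c1)Nc1ccc(Cl)c(Cl)c1` gives -2.98%
compound 3 `COc1cc(Cl)cc(-c2nn(-c3cccc(NC(=O)Nc4cc(C(F)(F)F)cc(C(F)(F)F)c4)c3)cc2-c2ccncc2)c1` gives -21.6%

Compound 2 stands second highest of the three numbers. Its nearest neighbour is compound 3, which lies beyond the scatter below it; the furthest is compound 1, which lies beyond the scatter above it. Among the compounds with values here, the only step that has been isolated within the set, a number 24.5 percentage points lower from compound 1 to compound 2 (beyond the scatter), turns on chloro in place of trifluoromethyl on an aromatic carbon and leaves the part of the molecule changed below untouched.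

Compound 4 `COc1cc(Cl)cc(-c2nn(-c3cccc(NC(=O)Nc4ccc(Cl)c(Cl)c4)c3)cc2-c2ccncc2)c1` is the next compound for this assay. It differs from compound 2 by methyl in place of hydrogen on an oxygen on an aromatic ring. Within the data shown here, compound 3 already carries the methoxy, but it differs from compound 2 in a second place as well, so its value and that of compound 2 show only that the methoxy-bearing member of the pair sits lower; the change from hydroxy to methoxy on its own has not been measured. Among the measured compounds shown here, no step therefore bears directly on it, and no movement beyond the scatter is expected, with a slight lean downward because compound 3 gives -21.6%.

For compound 4 the estimate in this assay is -10%, with a range from -35% to 15%. The expected step, a number 7 percentage points lower from compound 2 to compound 4 (within the scatter), is taken to stay within the usual scatter.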

Compound 4, a percentage reported as activity, at one concentration (the size of the read-out at that concentration, not a potency): -9.54%
Compound 4: the middle estimate sits 0.5 percentage points below what was measured, and the stated range covers the measured number.
By their numbers in this assay, from the lowest: compound 3; then compounds 4 and 2 (each within the scatter of the next); then compound 1.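

Working notes on the hydroxy position: in this assay, the change from hydroxy to methoxy on the 3-chloro-5-hydroxyphenyl group now has a direct reading, a number 6.6 percentage points lower from compound 2 to compound 4 (within the scatter). In this one pair, methyl in place of hydrogen on this oxygen therefore leaves the read-out at the one concentration tested within the usual scatter, so the free hydroxy is not required to keep it there. No available data explain this reading.

The reading comes from a single pair and says nothing yet about whether the same swap holds alongside the trifluoromethyl group of compound 1, which gives 21.5% in this assay. Also open is how far this position tolerates other replacements for the hydroxy, such as a longer ether like ethoxy, an amine or a carboxylic acid, since methoxy is the only alternative to hydroxy among the compounds shown.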